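Adding nitro to compound 2

The compounds below may be only part of what the source reports. "The series", "measured", "known", "first", "only" and "open" are said of these compounds alone.

In a functional assay on HFF cells (Homo sapiens) for cytotoxicity (on this read-out lower numbers stand for stronger inhibition and higher numbers for weaker inhibition), compound 1 `Nc1nc2cc(Cl)c(Cl)cc2n1C1O[C@H](CO)[C@@H](O)[C@H]1O` gives 32000 nM and compound 2 `OC[C@H]1OC(n2c(O)nc3cc(Cl)c(Cl)cc32)[C@H](O)[C@@H]1O` gives 100000 nM, the higher of the two numbers. Compound 3 `O=[N+]([O-])c1c(Cl)c(Cl)cc2c1nc(O)n2C1O[C@H](CO)[C@@H](O)[C@H]1O` differs from compound 2 by nitro in place of hydrogen on an aromatic carbon, with nitro in place of hydrogen on an aromatic carbon. For the measured compounds named here, the only measured step, a 3.1-fold higher number from compound 1 to compound 2 (0.49 log units; beyond the scatter), is modest and concerns a different change, hydroxy in place of amino, so it offers only a loose guide to size. In this assay, a step no larger than that one is expected, leaning towards a lower number. The estimated step is a 1.7-fold lower number from compound 2 to compound 3 (0.22 log units; within the scatter). Compound 3 is expected at 60000 nM, with an estimated range of 20000 nM to 180000 nM.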

Compound 3, half-maximal inhibitory concentration: 100000 nM
Beside the measured number, compound 3's estimate is 1.7-fold (0.22 log units) below it, and the stated range covers the measured number.
By their numbers in this assay, from the lowest: compound 1; then compounds 2 and 3 (each within the scatter of the next).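

In this assay the new step reads no change at the digits printed from compound 2 to compound 3 (within the scatter), so on this read-out the aromatic carbon ortho to a chloro group accepts nitro in place of hydrogen with no readable shift. The earlier step, a 3.1-fold higher number from compound 1 to compound 2 (0.49 log units; beyond the scatter), concerned only hydroxy in place of amino and said nothing about substitution at this ring position. No available data bear on why the number stays put.

As far as these compounds go, whether an amine or a methoxy group at this position would move the number remains open. Also open, from the compounds shown here alone, is whether nitro would behave the same way on compound 1, which carries amino in place of hydroxy.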